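This account rests on a few compounds, and the source may have more. Where it says the series, first, only, none or still open, it means among the compounds named here.

Measured so far:
compound 1 `O=C(Nc1cccc(-n2cc(-c3ccncc3)c(-c3ccc(Cl)c(O)c3)n2)c1)Nc1ccc(Cl)c(Cl)c1` — 24200 nM
compound 2 `COc1cc(-c2nn(-c3cccc(NC(=O)c4ccc(Cl)c(C(F)(F)F)c4)c3)cc2-c2ccncc2)ccc1Cl` — > 32500 nM

In a functional assay on NCI-H460 cells (Homo sapiens) for inhibition, read by sulforhodamine B assay, with a stated time of 48 h (a lower number here means that less compound is tolerated, a higher number that more compound is tolerated), compound 1 gives 24200 nM. Compound 2 reaches only the assay limit, > 32500 nM, so its true value is not a number; it stands at the limit of > 32500 nM in this assay, at which 1 of the 2 values shown sits. Going by the values given here, with nothing but a limit for compound 2, no measured step in this assay can be read against it. Compound 3 `COc1cc(-c2nn(-c3cccc(NC(=O)c4cccc(C(F)(F)F)c4)c3)cc2-c2ccncc2)ccc1Cl` is not yet measured. It differs from compound 2 by hydrogen in place of chloro on an aromatic carbon. Removing a single halogen from a weak pair is expected to shift little: a step that the limit leaves unreadable from compound 2 to compound 3 is estimated to stay within the scatter, most likely ending again at the limit. Compound 3 is expected near 38000 nM, with a range from 15000 nM to 90000 nM.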

Compound 3, concentration lethal to 50% of the cells: > 50000 nM
Compound 3: a limit, no number (the forecaster's own chance of this, stated with the estimate: 60%); middle value at least 1.3-fold (0.11 log units) away from the limit.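

Going by these compounds alone, compound 2 and compound 3 both stand only as limits, not numbers, so no step between them can be read. As far as these compounds go, whether hydrogen in place of chloro, 4-chloro-3-(trifluoromethyl)phenyl to 3-(trifluoromethyl)phenyl, changes the tolerated concentration at all stays open.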